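The source may hold more compounds than are shown below. What is called first, only, known or untested is meant among the compounds shown, and "the series" means these compounds.

Measured so far in an ADME assay on BJ cells (Homo sapiens) for cytotoxicity, with a stated time of 72 h; a higher number here means that more compound is needed for the effect, a lower number that less compound is needed:
- Compound 1, `C=C[C@@](C)(/C=C/c1ccc(OS(=O)(=O)C(F)(F)F)cc1)CCC=C(C)C`, gives only the limit of the assay, > 36600 nM.
- Compound 2, `C=C[C@@](C)(/C=C/c1ccc(OS(=O)(=O)c2ccc(C)cc2)cc1)CCC=C(C)C`, likewise gives only a limit, > 36600 nM.
- Compound 3, `C=C[C@@](C)(/C=C/c1ccc(Nc2ccc(OC)c(F)c2)cc1)CCC=C(C)C`, also gives only a limit, > 36600 nM.

Compound 1 therefore stands at no number at all: its result in this assay is a limit, and the two other results shown are limits too, which is what the limit of > 36600 nM in this assay, at which 3 of the 3 values shown sit, records. Going by the values given here, the only one-place step among the measured compounds, a step that the two limits leave unreadable from compound 1 to compound 2, cannot be read for the same reason, so no measured step gives a size to lean on.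

Compound 4 is `C=C[C@@](C)(/C=C/c1ccc(-c2ccccc2)cc1)CCC=C(C)C`. It differs from compound 1 by phenyl in place of ((trifluoromethyl)sulfonyl)oxy on an aromatic carbon. Among the compounds with values here, since every value shown sits at the limit and the one step is unreadable, no direction or size can be drawn from the measured compounds; the expectation is simply that nothing beyond the scatter will appear and that compound 4 will most likely return a limit again. Compound 4 is therefore estimated at 40000 nM, within 15000 nM to 100000 nM, which means an expected step that the limit leaves unreadable from compound 1 to compound 4.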

Compound 4, half-maximal effective concentration: > 36600 nM
Compound 4: a limit, no number; the forecaster's own chance of this, stated with the estimate: 80%; the middle value is on the limit's open side.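

Compound 4, like compound 1, gives only a limit and no number, so the step between these two compounds cannot be read: the limit of > 36600 nM in this assay, at which 4 of the 4 values shown sit.

The compounds shown leave open what concentration of any of them gives the half-maximal effect in this assay, and whether any single change alters it.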